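The compounds below may be only part of what the source reports. "The series", "measured", "known", "first", "only" and "open" are said of these compounds alone.

Measured so far:
Compound 1, `CC(C)C(C)Nc1cc(NC(=O)c2cccs2)cc(C(F)(F)F)c1`, gives in an assay on HEK293-TREx cells for antagonist activity at transient receptor potential cation channel subfamily A member 1 (Homo sapiens), read by calcium flux (on this read-out lower numbers stand for stronger inhibition and higher numbers for weaker inhibition), a value of 1300 nM.
Compound 2, `CCCNc1cc(NC(=O)c2cccs2)cc(C(F)(F)F)c1`, gives in this assay a value of 390 nM.

These two compounds share one core and differ only in the group attached to the ring nitrogen. For the measured compounds named here, compound 2 stands lowest of the two numbers; its only neighbour is compound 1, and the single measured step, a 3.3-fold lower number from compound 1 to compound 2 (0.52 log units; beyond the scatter), separates them. Compound 3, `CCCNc1cc(NC(=O)c2ccc(F)cc2)cc(C(F)(F)F)c1`, keeps the propyl group of compound 2 and changes the other end of the molecule: 4-fluorophenyl in place of thiophen-2-yl on a carbonyl carbon. Going by the values given here, no measured step bears on this part of the structure; the one step known concerns only the group on the ring nitrogen and says nothing about the amide side. With no guidance, the expectation for this assay is a step no larger than the scatter, in either direction, with wide uncertainty. Compound 3 is therefore estimated at 500 nM, with a range from 150 nM to 2000 nM. That estimate corresponds to an expected step of a 1.3-fold higher number from compound 2 to compound 3 (0.11 log units; within the scatter).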

Compound 3, half-maximal inhibitory concentration: 1400 nM
Compound 3: the middle estimate sits 2.8-fold (0.45 log units) below what was measured, and the stated range covers the measured number.
By their numbers in this assay, from the lowest: compound 2; then compounds 1 and 3 (each within the scatter of the next).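

With the propyl group held fixed, the group on the carbonyl carbon also matters in this assay: 4-fluorophenyl in place of thiophen-2-yl gives a 3.6-fold higher number from compound 2 to compound 3 (0.56 log units; beyond the scatter) and so moves the number away from stronger inhibition. For the compounds shown here, the earlier step concerned only the group on the ring nitrogen, so this is the first sign that the other end of the molecule also affects the read-out, with thiophen-2-yl the better of the two groups compared here. No measurement at hand explains why the number moves.

This single swap changes the ring size, removes the sulfur and adds the fluorine all at once, so the compounds shown cannot separate these changes; a plain phenyl or a furan-2-yl group on the carbonyl carbon would help to show which of them counts. From the compounds shown here alone, it also remains open whether the same step would appear with 1,2-dimethylpropyl or a longer chain such as butyl on the ring nitrogen.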